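Compound 4: 2,4-dichlorobenzyl in place of 2-bromophenyl on sulfur

The source may report more compounds than this note shows. Statements on the series, on what has been measured and on what is new or still open speak of the compounds shown alone.

In a functional assay on DU-145 cells (Homo sapiens) for inhibition, read by trypan blue exclusion, with a stated time of 96 h (a lower number here means a stronger inhibitor of growth, a higher number a weaker inhibitor of growth), compound 3 (`O=C(/C(=C\c1c(O)cc(O)cc1O)Sc1ccccc1Br)c1ccc(Cl)cc1`) gives > 100000 nM as its reading, and this is a limit of the assay, not a number. Two related compounds do give numbers in this assay: compound 1 (`Cc1ccc(CS/C(=C/c2c(O)cc(O)cc2O)C(=O)c2ccc(Cl)cc2)cc1`) gives 50000 nM and compound 2 (`O=C(/C(=C\c1c(O)cc(O)cc1O)SCc1ccc(Cl)c(Cl)c1)c1ccc(Cl)cc1`) gives 25000 nM with a benzyl group on the sulfur.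

Compound 4 (`O=C(/C(=C\c1c(O)cc(O)cc1O)SCc1ccc(Cl)cc1Cl)c1ccc(Cl)cc1`) carries 2,4-dichlorobenzyl in place of 2-bromophenyl on a sulfur. Within the data shown here, two measured steps bear on this change when read in reverse, since each puts 2-bromophenyl where a substituted benzyl stood. They are an at least 2.0-fold higher number from compound 1 to compound 3 (0.30 log units; that floor lies within the scatter) and an at least 4.0-fold higher number from compound 2 to compound 3 (0.60 log units; beyond the scatter) in the same assay. A change of substituents on the benzyl ring itself gave a 2.0-fold lower number from compound 1 to compound 2 (0.30 log units; within the scatter) and so offers little reason to set compound 4 apart from these two benzyl compounds.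

A lower number is therefore expected in this assay, by a modest margin. The expected change is an at least 3.3-fold lower number from compound 3 to compound 4 (0.52 log units; beyond the scatter) on this estimate. In this assay the estimated value for compound 4 is 30000 nM with an expected range of 10000 nM to 90000 nM around it.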

Compound 4, concentration for 50% growth inhibition: 25000 nM
Estimate against measurement, compound 4: 1.2-fold (0.08 log units) above; the measured number falls inside the stated range.
By their numbers in this assay, from the lowest: compounds 2, 4 and 1 (each within the scatter of the next). At a limit, above all of these: compound 3.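

In this assay, 2,4-dichlorobenzyl in place of 2-bromophenyl on a sulfur gives an at least 4.0-fold lower number from compound 3 to compound 4 (0.60 log units; beyond the scatter), so a second dichlorobenzyl compound now stands apart from compound 3 by a step beyond the scatter. The placing of the ring substituents shows no effect among the benzyl compounds: 2,4-dichlorophenyl in place of 3,4-dichlorophenyl gives no change at the digits printed from compound 2 to compound 4 (within the scatter), and 2,4-dichlorophenyl in place of 4-methylphenyl gives a 2.0-fold lower number from compound 1 to compound 4 (0.30 log units; within the scatter). The true size of the step from compound 3 stays unknown, as compound 3 stands at a limit and not at a number: the limit of > 100000 nM in this assay, at which 1 of the 4 values shown sits.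

The compounds shown leave open whether the step from compound 3 rests on the saturated chain carbon or on the ring substituents, a question that 2-bromobenzyl on the same sulfur would address directly. They also leave open how a longer chain such as 2-phenylethyl, or an amine or a carboxylic acid on the benzyl ring, would read in this assay.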